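Adding chloro to compound 3: what to expect

A few compounds are considered here, and "the series" means these few. Any claim that something is new, unique, unknown or untested is made for them only; others in the source may bear on it.

Measured in an ADME assay on a cell-free system (plasma, Rattus norvegicus) for metabolic stability, read by LC-MS, with a stated time of 60 min, tested at 100 uM; a lower number here means that less of the compound is left, a higher number that more of the compound is left:
compound 1 `Cc1cc(C(=O)O)ccc1OCCCCOc1ccc(C(=O)CC(C)C)c(O)c1C`: 100%
compound 2 `Cc1c(OCCCCOc2ccc(C(=O)O)cc2F)ccc(C(=O)CC(C)C)c1O`: 106%
compound 3 `Cc1c(OCCCCOc2ccc(C(=O)O)cc2)ccc(C(=O)CC(C)C)c1O`: 95%

Compound 3 gives 95%, level with compound 1 within the scatter, while compound 2 sits clearly higher.

Compound 4 `Cc1c(OCCCCOc2ccc(C(=O)O)cc2Cl)ccc(C(=O)CC(C)C)c1O` differs from compound 3 by one change: chloro in place of hydrogen on an aromatic carbon. For the measured compounds named here, no measured step involves chloro, but two steps change the same carbon. Hydrogen in place of methyl gave a number 5 percentage points lower from compound 1 to compound 3 (within the scatter), and hydrogen in place of fluoro gave a number 11 percentage points lower from compound 2 to compound 3 (beyond the scatter). Both steps remove a group and neither is large, so putting a group back on compound 3 should, if anything, raise the number slightly in this assay. The expected change is a number 5 percentage points higher from compound 3 to compound 4 (within the scatter), which is no clear shift. For compound 4 the estimated value is 100%, with an expected range of 88% to 112%.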

Compound 4, percent of the compound remaining: 123%
Compound 4: the middle estimate sits 23 percentage points below what was measured, and the stated range ends below it.
By their numbers in this assay, from the lowest: compounds 3, 1 and 2 (each within the scatter of the next, the first and the last beyond it); then compound 4.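

In this assay, the 4-carboxyphenyl to 4-carboxy-2-chlorophenyl change gives a number 28 percentage points higher from compound 3 to compound 4 (beyond the scatter), showing that a single chlorine atom on this aromatic carbon, ortho to a large group and meta to a carboxy group, can move the number well beyond what the methyl and fluoro compounds had shown. Chloro also separates from both of those groups at the same carbon, with a number 17 percentage points higher from compound 2 to compound 4 (beyond the scatter) and a number 23 percentage points higher from compound 1 to compound 4 (beyond the scatter), so compound 4 has the highest number of the four compounds and the identity of the group here matters, not merely whether a group is present. Nothing available explains why chloro stands apart from methyl and fluoro.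

On these data alone, whether bromo or methoxy on this same carbon would match or exceed chloro remains open. So does whether chloro on another carbon of this ring would give a similar step.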